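This account rests on a few compounds, and the source may have more. Where it says the series, first, only, none or still open, it means among the compounds named here.

Compound 1, whose structure is `COc1ccc(/C=C/C(=O)c2ccc(OC)c3c2OC(C)(C)C=C3)cc1OCCO`, is the starting point. In a functional assay on HepG2 cells (Homo sapiens) for cytotoxicity, read by MTT assay (a higher number here means a weaker inhibitor, a lower number a stronger inhibitor), compound 1 gives > 10000 nM, and that figure is a limit of the assay rather than a measured number, so compound 1 stands only at the weak end of what the assay can report. Two measured neighbours replace the 2-hydroxyethyl group on the same oxygen with an acyl group. Compound 2, with structure `C=CC(=O)Oc1cc(/C=C/C(=O)c2ccc(OC)c3c2OC(C)(C)C=C3)ccc1OC`, gives 160 nM in this assay, and compound 3, with structure `COc1ccc(/C=C/C(=O)c2ccc(OC)c3c2OC(C)(C)C=C3)cc1OC(=O)C1CC1`, gives 220 nM. The step from compound 1 to compound 2 is an at least 62-fold lower number from compound 1 to compound 2 (1.79 log units; beyond the scatter), and the step from compound 1 to compound 3 is an at least 45-fold lower number from compound 1 to compound 3 (1.65 log units; beyond the scatter). Between the two acyl groups the step is a 1.4-fold higher number from compound 2 to compound 3 (0.14 log units; within the scatter), so the two acyl variants cannot be told apart.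

Compound 4, with structure `COc1ccc(/C=C/C(=O)c2ccc(OC)c3c2OC(C)(C)C=C3)cc1OC(=O)c1ccco1`, makes the same kind of exchange on the same oxygen: (furan-2-yl)carbonyl in place of 2-hydroxyethyl on an oxygen on an aromatic ring. Both measured acyl replacements gave a large drop in the number, so a large drop is expected here too, estimated as an at least 45-fold lower number from compound 1 to compound 4 (1.65 log units; beyond the scatter). Compound 4 is expected to give 220 nM in this assay, within a range from 80 nM to 700 nM.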

Compound 4, half-maximal inhibitory concentration: 370 nM
Beside the measured number, compound 4's estimate is 1.7-fold (0.23 log units) below it; measured number inside the range.
By their numbers in this assay, from the lowest: compounds 2, 3 and 4 (each within the scatter of the next, the first and the last beyond it). At a limit, above all of these: compound 1.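

On this oxygen on an aromatic ring, an acyl group that carries a five-membered aromatic ring still gives a large change, with an at least 27-fold lower number from compound 1 to compound 4 (1.43 log units; beyond the scatter), so the drop is not confined to acyl groups ending in vinyl or cyclopropyl. Among these compounds, the group on the carbonyl carbon now begins to matter, though only slightly: furan-2-yl in place of cyclopropyl gives a 1.7-fold higher number from compound 3 to compound 4 (0.23 log units; within the scatter), so those two compounds cannot be told apart, while furan-2-yl in place of vinyl gives a 2.3-fold higher number from compound 2 to compound 4 (0.36 log units; beyond the scatter), a modest step that is the only one among the acyl compounds to pass beyond the scatter. Across compounds 2, 3 and 4, most of the change therefore goes with replacing 2-hydroxyethyl by an acyl group, and much less with which acyl group is chosen.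

Going by these compounds, the true size of that replacement stays open because compound 1 gives only a limit, not a measured number: the limit of > 10000 nM in this assay, at which 1 of the 4 values shown sits. Also open, on these data alone, is how an acyl group carrying an amine, a carboxylic acid or a longer carbon chain would behave on this oxygen, and whether a plain methyl group there would resemble compound 1 or the acyl compounds.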